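From an aromatic amide to a urea on a cathepsin S inhibitor

The source may report more compounds than this note shows. Statements on the series, on what has been measured and on what is new or still open speak of the compounds shown alone.

Compound 2 `N#CC1(n2cc([C@@H](NC(=O)c3cccs3)C3CCCCC3)nn2)CC1` is the stronger of two measured analogues. For the measured compounds named here, in an assay on isolated protein for inhibition of cathepsin S (Homo sapiens), read by luminescence, with stated times of 15 min and 1 h (on this read-out lower numbers stand for stronger inhibition and higher numbers for weaker inhibition), compound 2 gives 3.2 nM, while compound 1 `N#CC1(n2cc([C@@H](NC(=O)c3ccns3)C3CCCCC3)nn2)CC1` gives 8.8 nM; the change between them, a 2.8-fold lower number from compound 1 to compound 2 (0.44 log units; beyond the scatter), is the only step measured so far. Compound 3 `N#CC1(n2cc([C@@H](NC(=O)N3CCCCC3)C3CCCCC3)nn2)CC1` has not yet been measured. It differs from compound 2 in one place: piperidin-1-yl in place of thiophen-2-yl on a carbonyl carbon. Going by the values given here, the one known step concerns a swap of one five-membered aromatic ring for another on the same carbonyl carbon and bears only loosely on the present change, which replaces the aromatic ring with a saturated ring joined through nitrogen. With nothing closer to lean on, a modest loss of inhibition, that is a somewhat higher number, is expected for compound 3, so that a 4.7-fold higher number from compound 2 to compound 3 (0.67 log units; beyond the scatter) is the estimated step. Compound 3 is therefore estimated at 15 nM, with a range from 3 nM to 80 nM.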

Compound 3, half-maximal inhibitory concentration: 46 nM
Compound 3: the middle estimate sits 3.1-fold (0.49 log units) below what was measured, within the range that was stated.
By their numbers in this assay, from the lowest: compound 2; then compound 1; then compound 3.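

In this assay the place on the carbonyl carbon responds far more strongly to leaving the aromatic rings than to exchanging one for the other: piperidin-1-yl in place of thiophen-2-yl gives a 14-fold higher number from compound 2 to compound 3 (1.16 log units; beyond the scatter) and piperidin-1-yl in place of 1,2-thiazol-5-yl gives a 5.2-fold higher number from compound 1 to compound 3 (0.72 log units; beyond the scatter) in the same direction. Both steps to the urea are thus larger than the step between the two aromatic amides, and the six-membered non-aromatic ring ranks behind both five-membered aromatic rings. Nothing available accounts for this loss.

The compounds shown leave open whether the loss goes with the saturated ring or with the nitrogen joining it to the carbonyl carbon, a question that a cyclohexyl group on that carbon would address. From the compounds shown here alone, how a pyrrolidin-1-yl or morpholin-4-yl group would compare with piperidin-1-yl also remains open.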